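A few compounds are considered here, and "the series" means these few. Any claim that something is new, unique, unknown or untested is made for them only; others in the source may bear on it.

In a functional assay on SK-MEL-28 cells (Homo sapiens) for cytotoxicity, read by MTT assay, with a stated time of 72 h (a lower number here means a stronger inhibitor, a higher number a weaker inhibitor), three compounds have been measured:
compound 1 `COc1cc(/C=C/C=O)cc(OC)c1OC/C=C(\C)CCC=C(C)C` gives 26000 nM
compound 2 `CC(C)=CCOc1ccc(C(=O)/C=C/c2ccccc2)c(O)c1` gives 81000 nM
compound 3 `COc1cc(/C=C/C=O)cc(OC)c1OCC=C(C)C` gives 32000 nM

Compound 1 shares the low end of these numbers with compound 3, the two lying within the scatter of each other, and compound 2 reads higher than both. Compound 4 `COc1cc(/C=C/C=O)ccc1OC/C=C(\C)CCC=C(C)C` has not yet been measured. Its change from compound 1 is hydrogen in place of methoxy on an aromatic carbon. Among the compounds with values here, no measured step touches this methoxy. Within the data shown here, the one measured step, a 1.2-fold higher number from compound 1 to compound 3 (0.09 log units; within the scatter), lies in the chain and offers only weak guidance. No step beyond the scatter is therefore expected in this assay. The expected step is a 1.3-fold higher number from compound 1 to compound 4 (0.10 log units; within the scatter). For compound 4 the estimated value is 33000 nM, with an expected range from 15000 nM to 70000 nM.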

Compound 4, half-maximal inhibitory concentration: 28000 nM
Estimate against measurement, compound 4: 1.2-fold (0.07 log units) above; the range from low to high includes it.
By their numbers in this assay, from the lowest: compounds 1, 4 and 3 (each within the scatter of the next); then compound 2.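

In this assay the exchange of methoxy for hydrogen on this aromatic carbon gives a 1.1-fold higher number from compound 1 to compound 4 (0.03 log units; within the scatter) and so leaves the two compounds indistinguishable. Within the data shown here, the earlier compounds varied only the chain among close relatives, and this is the first sign that this methoxy can be lost from the core of compound 1 without a readable difference. No measured evidence speaks to the reason for this result. The compounds shown leave open whether a hydroxyl or an amine at this carbon would read the same, and whether the remaining methoxy can also be replaced by hydrogen.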